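A few compounds are considered here, and "the series" means these few. Any claim that something is new, unique, unknown or untested is made for them only; others in the source may bear on it.

Compound 3 `Cc1cc(C)c(CN2CCc3c(Cl)cc([C@@H](CO)[C@@H]4CCOC4)c(Cl)c3C2=O)c(=O)[nH]1` carries the highest number of the three in an assay on cells for inhibition of histone-lysine N-methyltransferase EZH2 (Homo sapiens), read by ELISA, with a stated time of 72 h (a lower number here means a stronger inhibitor, a higher number a weaker inhibitor), giving 2910 nM. Compound 1 `Cc1cc(C)c(CN2CCc3c(Cl)cc([C@H](CO)[C@H]4CCCO4)c(Cl)c3C2=O)c(=O)[nH]1` gives 40 nM and compound 2 `Cc1cc(C)c(CN2CCc3c(Cl)cc([C@H](CO)[C@@H]4CCCO4)c(Cl)c3C2=O)c(=O)[nH]1` gives 41 nM; the step of a 1.0-fold higher number from compound 1 to compound 2 (0.01 log units; within the scatter) is explained by the fact that compounds 1 and 2 differ only in the configuration as drawn. Compound 4 `Cc1cc(C)c(CN2CCc3c(Cl)cc([C@@H](CO)[C@@H]4CCCO4)c(Cl)c3C2=O)c(=O)[nH]1` differs from compound 3 by oxolan-2-yl in place of oxolan-3-yl on a saturated chain carbon bound to an aromatic carbon and a saturated chain carbon. The relevant steps are a 73-fold higher number from compound 1 to compound 3 (1.86 log units; beyond the scatter) and a 71-fold higher number from compound 2 to compound 3 (1.85 log units; beyond the scatter), both large, and compound 4 reverses that exchange, so a large step down in this assay is expected for a 15-fold lower number from compound 3 to compound 4 (1.16 log units; beyond the scatter). Compound 4 is expected at 200 nM, with a range of 30 nM to 1500 nM.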

Compound 4, half-maximal inhibitory concentration: 1570 nM
For compound 4 the middle estimate is 7.9-fold (0.89 log units) below the measured one, and the stated range ends below it.
By their numbers in this assay, from the lowest: compounds 1 and 2 (each within the scatter of the next); then compounds 4 and 3 (each within the scatter of the next).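

The exchange of oxolan-3-yl for oxolan-2-yl on its own changes little, with a 1.9-fold lower number from compound 3 to compound 4 (0.27 log units; within the scatter), so the ring attachment does not explain the weak number of compound 3. Inverting only the saturated chain carbon gives a 38-fold higher number from compound 2 to compound 4 (1.58 log units; beyond the scatter), and the mirror image gives a 39-fold higher number from compound 1 to compound 4 (1.59 log units; beyond the scatter). In this assay the large loss therefore follows the configuration at the chain carbon, not at the ring carbon: the fact that compounds 2 and 4 differ only in the configuration as drawn

The compounds shown leave open whether oxolan-3-yl with the chain carbon inverted would match compound 1. They also leave open whether a cyclopentyl group or a pyrrolidine amine could replace the oxolane ring.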